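This account rests on a few compounds, and the source may have more. Where it says the series, first, only, none or still open, it means among the compounds named here.

Compound 3 `CCN(c1nc(Cl)nc(N[C@H](C)c2ccccc2)n1)C(C)C` gives 52500 nM in an ADME assay on the whole organism for inhibition, with Echinochloa crus-galli var. formosensis as the target, with a stated time of 4 days (a lower number here means a stronger inhibitor, a higher number a weaker inhibitor), the highest of the three numbers measured; compound 1 `CC(C)Nc1nc(Cl)nc(N[C@@H](C)c2ccccc2)n1` gives 11000 nM and compound 2 `CC(C)N(c1nc(Cl)nc(N[C@H](C)c2ccccc2)n1)C(C)C` gives 6610 nM. Compound 4 `CC(C)Nc1nc(Cl)nc(N[C@H](C)c2ccccc2)n1` is obtained from compound 3 by hydrogen in place of ethyl on a nitrogen on an aromatic ring. Among the measured compounds shown here, one measured step bears on this: trimming the same nitrogen's substituent, hydrogen in place of methyl on a saturated chain carbon bound to that nitrogen, gave a 7.9-fold higher number from compound 2 to compound 3 (0.90 log units; beyond the scatter). Compound 1, which differs from compound 4 only in spatial arrangement at one carbon, sits well below compound 3. Compound 4 is therefore expected to give 12000 nM, between 3000 nM and 50000 nM, an estimated step of a 4.4-fold lower number from compound 3 to compound 4 (0.64 log units; beyond the scatter).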

Compound 4, half-maximal inhibitory concentration: 2000 nM
Compound 4: the middle estimate sits 6.0-fold (0.78 log units) above what was measured, outside the stated range (below it).
By their numbers in this assay, from the lowest: compound 4; then compounds 2 and 1 (each within the scatter of the next); then compound 3.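

In this assay, replacing ethyl with hydrogen on the nitrogen on the aromatic ring gave a 26-fold lower number from compound 3 to compound 4 (1.42 log units; beyond the scatter), while replacing isopropyl with hydrogen gave a 3.3-fold lower number from compound 2 to compound 4 (0.52 log units; beyond the scatter). Among these compounds, a nitrogen carrying hydrogen and isopropyl therefore gives the lowest number. The same group also depends on the drawn configuration at the stereocentre, with a 5.5-fold lower number from compound 1 to compound 4 (0.74 log units; beyond the scatter), and this gap can only come from that difference: the fact that compounds 1 and 4 differ only in the configuration as drawn

The compounds shown leave open whether a butyl chain or a cyclopropyl ring in place of isopropyl would keep the number as low. As far as these compounds go, whether the configuration gap persists with two carbon groups on this nitrogen also stays open.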